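A few compounds are considered here, and "the series" means these few. Any claim that something is new, unique, unknown or untested is made for them only; others in the source may bear on it.

Working notes on the series, in an ADME assay on HepG2 cells (Homo sapiens) for cytotoxicity, read by MTT assay, with a stated time of 72 h; a higher number here means that more compound is tolerated, a lower number that less compound is tolerated. Compound 1 (`COc1ccc(-c2cc(Cl)cn3c([N+](=O)[O-])c(CS(=O)(=O)c4ccccc4)nc23)cc1`) reads > 3900 nM, and this is a limit of the assay, not a number. For the measured compounds named here, compound 2 (`O=[N+]([O-])c1c(CS(=O)(=O)c2ccccc2)nc2c(-c3ccccc3CO)cc(Cl)cn12`) gives 88000 nM, the only true number so far, so its rank cannot be stated.

Compound 3 (`O=[N+]([O-])c1c(CS(=O)(=O)c2ccccc2)nc2c(-c3ccc(F)cc3)cc(Cl)cn12`) carries 4-fluorophenyl in place of 2-(hydroxymethyl)phenyl on an aromatic carbon, ortho to a fused ring and meta to a chloro group: 4-fluorophenyl in place of 2-(hydroxymethyl)phenyl on an aromatic carbon.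

Going by the values given here, one measured step bears on this change, as it replaces the group at the same place: a step that the limit leaves unreadable from compound 1 to compound 2. It has no usable size, so the direction below is a tentative expectation. With 4-methoxyphenyl in that place, compound 1 offers only its limit of > 3900 nM, which leaves room for a value well short of that of compound 2.

A move towards less compound tolerated in this assay is therefore expected, and a report as a limit is quite possible. The estimated step is a 3.5-fold lower number from compound 2 to compound 3 (0.55 log units; beyond the scatter). For compound 3 the expected value is 25000 nM, with an estimated range of 5000 nM to 100000 nM.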

Compound 3, half-maximal cytotoxic concentration: > 15600 nM
Compound 3 gave a limit, no number; the forecaster's own chance of this, stated with the estimate: 55%; the middle value does not contradict the limit.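

For the compounds shown here, compound 3 reads > 15600 nM, which is a limit and not a number, so no step among compound 1, compound 2 and compound 3 can be read. The compounds shown leave open how the true values of compound 1 and compound 3, with 4-methoxyphenyl and 4-fluorophenyl, compare with that of compound 2, with 2-(hydroxymethyl)phenyl, in this assay.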